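Halogen shift on the aryl ring of the shared core

The source may report more compounds than this note shows. Statements on the series, on what has been measured and on what is new or still open speak of the compounds shown alone.

Measured so far in an assay on HEK293 cells for displacement of a labelled ligand from Neuronal acetylcholine receptor; alpha3/beta4 (Homo sapiens); on this read-out lower numbers stand for stronger inhibition and higher numbers for weaker inhibition:
compound 1 `Cc1ccc(Nc2cncc(N3CC4CC(C3)N4)c2)cc1` gives 1.4 nM
compound 2 `Oc1ccc(Nc2cncc(N3CC4CC(C3)N4)c2)cc1` gives 0.988 nM
compound 3 `Fc1ccc(Nc2cncc(N3CC4CC(C3)N4)c2)cc1` gives 1.25 nM

Compound 3 stands second highest of the three numbers in this assay. The steps between the measured compounds are a 1.1-fold lower number from compound 1 to compound 3 (0.05 log units; within the scatter), a 1.3-fold higher number from compound 2 to compound 3 (0.10 log units; within the scatter) and a 1.4-fold lower number from compound 1 to compound 2 (0.15 log units; within the scatter); each is within the scatter, so the three compounds cannot be ordered.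

Compound 4 `Clc1cccc(Nc2cncc(N3CC4CC(C3)N4)c2)c1` differs from compound 3 as follows: 3-chlorophenyl in place of 4-fluorophenyl on a nitrogen on an aromatic ring. All three measured steps exchange one group on an aromatic carbon of this ring, and none of them moved the number beyond the scatter; they bear on the present step only loosely, as none exchanges one halogen for another at a different place. The expectation is therefore no step beyond the scatter: a 1.3-fold higher number from compound 3 to compound 4 (0.11 log units; within the scatter). Compound 4 is estimated at 1.6 nM, with a range from 0.6 nM to 4.5 nM.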

Compound 4, inhibition constant: 293 nM
Compound 4: the middle estimate sits 180-fold (2.26 log units) below what was measured, and the stated range ends below it.
By their numbers in this assay, from the lowest: compounds 2, 3 and 1 (each within the scatter of the next); then compound 4.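

In this assay, for the compounds shown here, the move to 3-chlorophenyl gives a 230-fold higher number from compound 3 to compound 4 (2.37 log units; beyond the scatter) and a 300-fold higher number from compound 2 to compound 4 (2.47 log units; beyond the scatter) and also a 210-fold higher number from compound 1 to compound 4 (2.32 log units; beyond the scatter) as the first steps beyond the scatter. The aryl group on this nitrogen is thus not indifferent to change, although the 4-methylphenyl, 4-hydroxyphenyl and 4-fluorophenyl groups could not be ordered. Nothing available explains the step.

The compounds shown change the halogen and its place together, so they cannot separate the two. A 4-chlorophenyl or 3-fluorophenyl group would address this, and a 3-methylphenyl group would show whether the loss is specific to chlorine.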